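A few compounds are considered here, and "the series" means these few. Any claim that something is new, unique, unknown or untested is made for them only; others in the source may bear on it.

Measured compounds:
compound 1, `O=c1cc(/C=N\c2ccccc2O)c2c(OCc3ccccc3)cc(OCc3ccccc3)cc2o1`, 7760 nM
compound 2, `O=c1cc(/C=N\O)c2c(OCc3ccccc3)cc(OCc3ccccc3)cc2o1`, 38700 nM
compound 3, `O=c1cc(/C=N\O)c2ccc(OCc3ccccc3)cc2o1`, 22800 nM

In a functional assay, read by spectrophotometry, with a stated time of 3 min (on this read-out higher numbers stand for weaker inhibition and lower numbers for stronger inhibition), compound 2 stands with the highest of the three numbers. Its nearest neighbour is compound 3, and the difference a 1.7-fold lower number from compound 2 to compound 3 (0.23 log units; within the scatter) lies within the scatter; the furthest is compound 1, and the difference a 5.0-fold higher number from compound 1 to compound 2 (0.70 log units; beyond the scatter) lies beyond it.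

Compound 4, `O=c1cc(/C=N\c2ccc(O)cc2)c2c(OCc3ccccc3)cc(OCc3ccccc3)cc2o1`, has not yet been measured. It differs from compound 2 by 4-hydroxyphenyl in place of hydroxy on a double-bonded nitrogen. Among the compounds with values here, the only measured step that bears on this change is the one between compound 1 and compound 2, where the aryl group on the double-bonded nitrogen gave way to hydroxy and the number rose by a 5.0-fold higher number from compound 1 to compound 2 (0.70 log units; beyond the scatter). Within the data shown here, compound 4 reverses that kind of change, though with the hydroxy at a different position on the ring, so no measured pair speaks to the exact group. A step of roughly that size in the lowering direction is therefore expected in this assay, with wide uncertainty. For compound 4 the estimate is 10000 nM, with a range of 3500 nM to 30000 nM, which would mean an expected step of a 3.9-fold lower number from compound 2 to compound 4 (0.59 log units; beyond the scatter).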

Compound 4, half-maximal inhibitory concentration: 3570 nM
Compound 4: the middle estimate sits 2.8-fold (0.45 log units) above what was measured; low and high end bracket the measured number.
By their numbers in this assay, from the lowest: compound 4; then compound 1; then compounds 3 and 2 (each within the scatter of the next).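

In this assay, replacing hydroxy on the double-bonded nitrogen with 4-hydroxyphenyl gives an 11-fold lower number from compound 2 to compound 4 (1.04 log units; beyond the scatter), so a second aryl group at this place goes with stronger inhibition than hydroxy, and that gain is not confined to the 2-hydroxyphenyl group. The placement of the hydroxy on the aryl ring also counts, as the change from 2-hydroxyphenyl to 4-hydroxyphenyl gives a 2.2-fold lower number from compound 1 to compound 4 (0.34 log units; beyond the scatter). Nothing available explains why either change goes with stronger inhibition.

The compounds shown leave open whether the hydroxy on the aryl ring is needed at all, since neither an unsubstituted phenyl nor an aminophenyl or carboxyphenyl group appears at this place. They also leave open whether 4-hydroxyphenyl would bring a similar step on the core of compound 3, where hydrogen stands in place of a benzyloxy.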